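T-type channel series: trimming the biaryl of compound 2

A few compounds are considered here, and "the series" means these few. Any claim that something is new, unique, unknown or untested is made for them only; others in the source may bear on it.

Measured compounds:
- compound 1, `CN(C)CCCCCSC1=Nc2ccccc2C(CC(=O)NCc2ccccc2)N1c1ccccc1`: 3200 nM
- compound 2, `CN(C)CCCCCSC1=Nc2ccccc2C(CC(=O)NCc2ccc(F)cc2)N1c1ccc(-c2ccc(F)cc2)cc1`: 960 nM

In an assay on cells for inhibition of Voltage-dependent T-type calcium channel subunit alpha-1I (Homo sapiens), read by patch clamp (a lower number here means a stronger inhibitor, a higher number a weaker inhibitor), compound 2 gives 960 nM, the lowest of the two numbers; the nearest is compound 1 with 3200 nM, a gap beyond the scatter. Compound 3, `CN(C)CCCCCSC1=Nc2ccccc2C(CC(=O)NCc2ccc(F)cc2)N1c1ccccc1`, is not yet measured. It differs from compound 2 by hydrogen in place of 4-fluorophenyl on an aromatic carbon. Within the data shown here, no step between measured compounds covers this change; compound 1 and compound 2 differ in two places at once, so only their two values are known. A moderate loss is expected, so the step of a 2.6-fold higher number from compound 2 to compound 3 (0.42 log units; beyond the scatter) is an estimate, not a measurement. For compound 3 the expected value is 2500 nM, within 1000 nM to 6500 nM.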

Compound 3, half-maximal inhibitory concentration: "not active" (no number reported)
Compound 3: no number reported; no gap can be computed for the estimate.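

Among these compounds, compound 3 is reported as not active in this assay, without a number, so no step from compound 2 can be read. From the compounds shown here alone, how much the 4-fluorophenyl matters to compound 2 remains open. No available evidence bears on this result.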